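Extending an Ester Chain on Two Related Cores

The source may hold more compounds than are shown below. What is called first, only, known or untested is meant among the compounds shown, and "the series" means these compounds.

Compound 1 `COC(=O)C1=C(C)NC(=S)NC1c1ccoc1` and compound 2 `CCCOC(=O)C1=C(C)NC(=S)NC1c1ccoc1` share one core, while compound 3 `COC(=O)C1=C(C)N(C)C(=O)NC1c1ccco1` and the not yet measured compound 4 `CCCOC(=O)C1=C(C)N(C)C(=O)NC1c1ccco1` share another; the difference between the two cores is not broken down here. In an assay on membranes from HeLa cells for displacement of a labelled ligand from adenosine receptor A3 (Homo sapiens), read by scintillation counting, with a stated time of 180 min, tested at 1 uM (on this read-out higher numbers stand for more inhibition at the one concentration tested (going by the name of the read-out) and lower numbers for less inhibition), compound 1 gives 3% and compound 2 gives 3%. In this assay compound 3 gives 9%. The change from compound 1 to compound 2 is ethyl in place of hydrogen on a saturated chain carbon bound to an oxygen next to a carbonyl group, and it produced no change at the digits printed from compound 1 to compound 2 (within the scatter). Compound 4 carries the same change on the second core, namely (ethyl in place of hydrogen on a saturated chain carbon bound to an oxygen next to a carbonyl group). The expectation for compound 4 rests on compound 1 and compound 2, whose step was no change at the digits printed from compound 1 to compound 2 (within the scatter). For compound 4 the expected step is no change at the digits printed from compound 3 to compound 4 (within the scatter). In this assay compound 4 is therefore expected to give about 9%, most likely between -2% and 20%.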

Compound 4, a percentage reported as inhibition, at one concentration (the size of the read-out at that concentration, not a potency): 8%
The estimate for compound 4 lay 1 percentage points above the measured number, and the stated range covers the measured number.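

In this assay, swapping methoxycarbonyl for propoxycarbonyl gives a number 1 percentage points lower from compound 3 to compound 4 (within the scatter). Set beside the earlier step, the change looks the same on both cores: the same change on two cores in this assay, no change at the digits printed (within the scatter) from compound 1 to compound 2 and a number 1 percentage points lower (within the scatter) from compound 3 to compound 4, 1 percentage points apart, within the scatter of two such steps. This shows that the change carried over between these two cores without a visible shift in the read-out, but all four compounds give only small numbers at the one concentration tested. It therefore does not show whether the change would carry over to a core with much stronger inhibition, and it gives no measure of potency.

The compounds shown leave open what a longer chain, such as butyl, or a benzyl group would do in this position. They also leave open the effect of an amine at the end of the chain.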